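From acetyl to 4-methoxyoxan-4-yl on compound 3

The source may report more compounds than this note shows. Statements on the series, on what has been measured and on what is new or still open speak of the compounds shown alone.

In an ADME assay for pharmacokinetics, read by HPLC (on this read-out higher numbers stand for a longer-lived compound and lower numbers for a shorter-lived compound), compound 3 `CC(=O)O[C@@H]1/C=C(\C)CC[C@]2([C@@](C)(O)C(=O)SCc3oc(=O)oc3C)CC(=O)N([C@H](C)c3nc(cs3)/C=C/C=C/C1=O)[S+]2[O-]` gives 24 h, and compound 1 `COCO[C@@H]1/C=C(\C)CC[C@]2([C@@](C)(O)C(=O)SCc3oc(=O)oc3C)CC(=O)N([C@H](C)c3nc(cs3)/C=C/C=C/C1=O)[S+]2[O-]` gives 24 h, so the two stand level. Compound 2 `C/C1=C\[C@@H](O)C(=O)/C=C/C=C/c2csc(n2)[C@@H](C)N2C(=O)C[C@@]([C@@](C)(O)C(=O)SCC(=O)OC(C)(C)C)(CC1)[S+]2[O-]` reads > 24 h, which is a limit of the assay and not a number. The top of the scale is therefore in view, with the limit of > 24 h in this assay, at which 1 of the 3 values shown sits.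

Compound 4 `COC1(O[C@@H]2/C=C(\C)CC[C@]3([C@@](C)(O)C(=O)SCc4oc(=O)oc4C)CC(=O)N([C@H](C)c4nc(cs4)/C=C/C=C/C2=O)[S+]3[O-])CCOCC1` carries 4-methoxyoxan-4-yl in place of acetyl on an oxygen on a saturated carbon. Among the measured compounds shown here, only one measured step bears on this change. It has acetyl in place of methoxymethyl on the same oxygen, and it reads no change at the digits printed from compound 1 to compound 3 (within the scatter). That makes a single step of no visible size, and it is thin support, as the entering group brings one six-membered non-aromatic ring that neither acetyl nor methoxymethyl has.

For the measured compounds named here, with only that step from compound 1 to compound 3 to go on, no shift beyond the scatter is expected in this assay. The expected change is no change at the digits printed from compound 3 to compound 4 (within the scatter), with no direction favoured. Compound 4 is estimated at 24 h, with an expected range from 12 h to 36 h, and it may also be reported only as a limit.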

Compound 4, half-life: 18 h
Beside the measured number, compound 4's estimate is 1.3-fold (0.12 log units) above it; low and high end bracket the measured number.
By their numbers in this assay, from the lowest: compounds 4, 1 and 3 (each within the scatter of the next).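

The earlier step compared only acetyl and methoxymethyl on this oxygen, whereas 4-methoxyoxan-4-yl brings one six-membered non-aromatic ring that neither of them has, and in this assay the reading is a 1.3-fold lower number from compound 3 to compound 4 (0.12 log units; within the scatter), with a 1.3-fold lower number from compound 1 to compound 4 (0.12 log units; within the scatter). The oxygen on a saturated carbon thus now carries three different groups in compounds 1, 3 and 4, all within the scatter of one another, so this ring-bearing group leaves the half-life unmoved as far as this read-out can tell. Compound 4 gives a plain number rather than a limit, but the read-out does have a ceiling, and any reading of this series has to be set against it: the limit of > 24 h in this assay, at which 1 of the 4 values shown sits.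

The compounds shown leave open whether a group of another kind on this oxygen, such as an amine or a carboxylic acid, would shift the half-life beyond the scatter. They also leave open whether a longer chain or a ring without the methoxy group would read the same as 4-methoxyoxan-4-yl does here.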